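The compounds below may be only part of what the source reports. "The series", "measured", "known", "first", "only" and "open" are said of these compounds alone.

Measured in an ADME assay (liver) for metabolic stability, with Liver microsome (Homo sapiens) as the target, using microsomes, tested at 1 uM; on this read-out higher numbers stand for fast clearance and lower numbers for slow clearance:
- compound 1 `CCC1=C(c2cc(OC)c(OC)c(OC)c2)c2ccc(OC)c(O)c2CCC1`: 136 mL.min-1.g-1
- compound 2 `COc1ccc2c(c1O)CCCC=C2c1cc(OC)c(OC)c(OC)c1`: 54.1 mL.min-1.g-1

Of these two, compound 2 stands lowest, at 54.1 mL.min-1.g-1. Compound 3 `COc1ccc2c(c1O)CCCC(Cc1ccccc1)=C2c1cc(OC)c(OC)c(OC)c1` differs from it as follows: benzyl in place of hydrogen on a double-bonded ring carbon. Within the data shown here, only one measured step bears on this change: a 2.5-fold lower number from compound 1 to compound 2 (0.40 log units; beyond the scatter), a modest step with hydrogen in place of ethyl. Read in reverse, it leads to the expectation of a similarly modest rise in this assay when benzyl enters. The expected step is a 2.4-fold higher number from compound 2 to compound 3 (0.38 log units; beyond the scatter). Compound 3 is estimated at 130 mL.min-1.g-1, with an expected range of 60 mL.min-1.g-1 to 280 mL.min-1.g-1.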

Compound 3, intrinsic clearance in microsomes: 51.2 mL.min-1.g-1
Beside the measured number, compound 3's estimate is 2.5-fold (0.40 log units) above it, and the stated range ends above it.
By their numbers in this assay, from the lowest: compounds 3 and 2 (each within the scatter of the next); then compound 1.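

Benzyl in place of hydrogen on the double-bonded ring carbon gives, in this assay, a 1.1-fold lower number from compound 2 to compound 3 (0.02 log units; within the scatter) and so leaves the read-out within the scatter. Phenyl in place of methyl on the saturated chain carbon gives a 2.7-fold lower number from compound 1 to compound 3 (0.42 log units; beyond the scatter) and so shows that ethyl and benzyl at this place do not read alike: the step seen with ethyl does not carry over to benzyl. Nothing at hand explains this difference. Going by these compounds, whether a methyl, a longer chain or an amine here would read like ethyl or like benzyl stays open.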